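The source may hold more compounds than are shown below. What is called first, only, known or untested is meant among the compounds shown, and "the series" means these compounds.

Compound 1 `Cc1c(-c2cc(Cl)cc(Cl)c2)c(C(=O)O)nn1-c1nc(-c2cccnc2)c(SC(C)C)s1` gives "not active" (no number reported) in a functional assay on BJAB cells (Homo sapiens) for antiproliferative activity, with a stated time of 4 days; on this read-out higher numbers stand for an effect only at larger amounts of compound and lower numbers for an effect already at smaller amounts.
Compound 2 `Cc1c(-c2cc(Cl)cc(Cl)c2)c(C(=O)O)nn1-c1nc(-c2cnn(C)c2)c(SC(C)C)s1` gives "not active" (no number reported) in this assay.
Compound 3 `Cc1cc(C#N)cc(-c2c(C)nn(-c3nc(-c4ccc(Cl)c(Cl)c4)c(SC(C)C)s3)c2C(=O)O)c1` gives 4800 nM in this assay.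

Compound 3 is therefore the only one of the three with a reported number in this assay; compound 1 and compound 2 are reported without one. Compound 4 `CC(=O)Nc1ccc(-c2c(C)nn(-c3nc(-c4ccc(Cl)c(Cl)c4)c(SC(C)C)s3)c2C(=O)O)cc1` differs from compound 3 in one place: 4-acetamidophenyl in place of 3-cyano-5-methylphenyl on an aromatic carbon. Among the compounds with values here, no measured pair of this kind is at hand, so the direction of the step is open. Within the data shown here, compound 4 is expected to stay close to compound 3, with the estimated step of a 1.0-fold higher number from compound 3 to compound 4 (0.02 log units; within the scatter) not beyond the usual scatter, since the only anchor is compound 3 at 4800 nM. Compound 4 is estimated at 5000 nM, with a range from 1500 nM to 20000 nM.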

Compound 4, half-maximal effective concentration: 139000 nM
Beside the measured number, compound 4's estimate is 28-fold (1.44 log units) below it; the whole stated range lies below it.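

In this assay, the result shows that this aromatic carbon, next to the ring atom that bears a carboxy group, is sensitive to the choice of aryl group: 4-acetamidophenyl in place of 3-cyano-5-methylphenyl gives a 29-fold higher number from compound 3 to compound 4 (1.46 log units; beyond the scatter). Both groups carry a six-membered aromatic ring of carbon only, so the step comes with a change in what that ring carries, not in the ring itself. No measurement at hand accounts for the step. On these data alone, it remains open whether the higher number follows from gaining the acetamido group or from losing the nitrile and methyl groups. Where a 4-aminophenyl or an unsubstituted phenyl group would fall is also open.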